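Acetyl in Place of Hydrogen: Expectation for Compound 3

This account rests on a few compounds, and the source may have more. Where it says the series, first, only, none or still open, it means among the compounds named here.

Measured so far:
Compound 1, `C=C1C(=O)O[C@]2(C)CC[C@@H]1C[C@H](O)[C@@]1(C)CC[C@H](OC(C)=O)[C@@](C)(CCC2=O)O1`, gives < 20 ug/mL in a functional assay on Doay cells (Homo sapiens) for cytotoxicity, read by MTT assay; on this read-out higher numbers stand for an effect only at larger amounts of compound and lower numbers for an effect already at smaller amounts; this value is a limit of the assay.
Compound 2, `C=C1C(=O)O[C@]2(C)CC[C@@H]1C[C@H](O)[C@@]1(C)CC[C@H](O1)[C@](C)(O)CC[C@H]2OC(C)=O`, gives < 20 ug/mL in this assay; this value is a limit of the assay.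

For the measured compounds named here, compound 2 therefore stands only at a limit, and the one further value shown is a limit as well: the limit of < 20 ug/mL in this assay, at which 2 of the 2 values shown sit. Going by the values given here, no pair of measured compounds differs in one place, so no measured step is available, and the data do not tell how large a change in this assay a single substitution produces.

Compound 3, `C=C1C(=O)O[C@]2(C)CC[C@@H]1C[C@H](OC(C)=O)[C@@]1(C)CC[C@H](O1)[C@](C)(O)CC[C@H]2OC(C)=O`, is the next compound to be measured. It differs from compound 2 in one place: acetyl in place of hydrogen on an oxygen on a saturated carbon. The same difference, read one bond further out, is hydroxy to acetoxy. Among the compounds with values here, with no measured step in hand, the author expects no step beyond the usual scatter from compound 2 to compound 3 in this assay, that is a step that the limit leaves unreadable from compound 2 to compound 3. Compound 3 is accordingly expected to give about 10 ug/mL in this assay, within a range from 3 ug/mL to 20 ug/mL, and most likely to be reported again only as a limit.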

Compound 3, concentration for half-maximal effect: < 20 ug/mL
Compound 3 was reported as a limit; the forecaster's own chance of this, stated with the estimate: 70%; the middle value is on the limit's open side.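

In this assay compound 3 gives < 20 ug/mL, which is a limit of the assay. Compound 2 also stands only at a limit, so no step can be read between compound 2 and compound 3: the limit of < 20 ug/mL in this assay, at which 3 of the 3 values shown sit.

The compounds shown leave open where their actual values lie in this assay, and whether acetyl in place of hydrogen changes the read-out at all.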